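The source may report more compounds than this note shows. Statements on the series, on what has been measured and on what is new or still open speak of the compounds shown alone.

Compound 1 `Cc1cc(Nc2cc(Cl)c(C)c(Cl)c2)nc(N)n1`, compound 2 `Cc1cc(Nc2cc(Cl)c(OC(F)F)c(Cl)c2)nc(N)n1`, compound 3 `Cc1cc(Nc2cc(Cl)c(N(C)C)c(Cl)c2)nc(N)n1`.

In an assay on cells for inhibition of S-adenosylmethionine decarboxylase proenzyme (Homo sapiens), read by mass spectrometry, at pH 7.2 (a higher number here means a weaker inhibitor, a lower number a stronger inhibitor), compound 1 gives only a limit, > 63000 nM. In this assay compound 2 likewise gives only a limit, > 63000 nM. Compound 3 too gives only a limit, > 180000 nM. Compound 3 thus stands at the limit of > 180000 nM in this assay, at which 1 of the 3 values shown sits. The other two values sit at the limit of > 63000 nM in this assay, at which 2 of the 3 values shown sit, so none of the three is a number. The steps a step that the two limits leave unreadable from compound 1 to compound 2, a step that the two limits leave unreadable from compound 1 to compound 3 and a step that the two limits leave unreadable from compound 2 to compound 3 are therefore all unreadable in size. Compound 4 `Cc1cc(Nc2cc(Cl)c(N3CCCCC3)c(Cl)c2)nc(N)n1` differs from compound 3 by piperidin-1-yl in place of dimethylamino on an aromatic carbon. Among the compounds with values here, no measured step reads the effect of such a change, so compound 4 is expected to stay at a limit, with an expected step that the limit leaves unreadable from compound 3 to compound 4. Compound 4 is estimated at 200000 nM, between 60000 nM and 600000 nM.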

Compound 4, half-maximal inhibitory concentration: > 180000 nM
Compound 4: no number, only a limit; the forecaster's own chance of this, stated with the estimate: 85%; the middle value lies beyond the limit too.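

In this assay compound 4 gives only a limit, > 180000 nM, so its steps from compound 1, compound 2 and compound 3 cannot be read. The compounds shown leave open whether any of these groups gives a measurable inhibitory concentration.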